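Series notes: ester to isopropyl amide on the diene chain

The source may hold more compounds than are shown below. What is called first, only, known or untested is meant among the compounds shown, and "the series" means these compounds.

In a physicochemical assay for lipophilicity (a higher number here means a more lipophilic compound, a lower number a more polar compound), compound 2 `COC(=O)/C=C(C)/C=C/CC(C)CCCC(C)(C)OC` gives 5, the lowest of the three numbers measured. Within the data shown here, compound 1 `COC(=O)/C=C(C)/C=C/CC(C)CCCC(C)C` gives 6.2, and the step of a number 1.20 log units lower from compound 1 to compound 2 (beyond the scatter) is the only single-site step measured. Compound 3 `CCNC(=O)OC(C)(C)CCCC(C)C/C=C/C(C)=C/C(=O)OC(C)C` gives 6.06, differing from compound 2 at more than one place, so only the two values themselves can be compared. Compound 4 `COC(C)(C)CCCC(C)C/C=C/C(C)=C/C(=O)NC(C)C` differs from compound 2 as follows: isopropylamino in place of methoxy on a carbonyl carbon. Among the measured compounds shown here, no measured step covers this kind of change, so the expectation rests on the value of compound 2 alone and carries a wide range. For compound 4 the expected step is a number 0.50 log units lower from compound 2 to compound 4 (beyond the scatter) in this assay, and compound 4 is estimated at 4.5, between 3.7 and 5.3.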

Compound 4, partition coefficient: 4.45
Compound 4: the middle estimate sits 0.05 log units above what was measured, within the range that was stated.
By their numbers in this assay, from the lowest: compound 4; then compound 2; then compounds 3 and 1 (each within the scatter of the next).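

Isopropylamino in place of methoxy on a carbonyl carbon gives a number 0.55 log units lower from compound 2 to compound 4 (beyond the scatter) in this assay, so the carbonyl end of the chain also moves this number. Among these compounds, the only earlier single-site step, a number 1.20 log units lower from compound 1 to compound 2 (beyond the scatter), lay on a saturated chain carbon instead. Nothing available explains the new step.

As far as these compounds go, whether the step recurs with the hydrogen-bearing chain of compound 1 remains open. Also open, from the compounds shown here alone, is how a carboxylic acid or a dimethylamino group on this carbonyl carbon would read.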